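A few compounds are considered here, and "the series" means these few. Any claim that something is new, unique, unknown or untested is made for them only; others in the source may bear on it.

Compound 1 `CCCCc1ccc2[nH]c(-c3ccc(OC)cc3)c(/C=N/NC(=O)c3ccc(F)cc3)c2c1` measures 91 nM
Compound 2 `CCCCc1ccc2[nH]c(-c3ccc(OC)cc3)c(/C=N/NC(=O)c3ccccc3OC)c2c1` measures 74 nM

Within the data shown here, in a functional assay on HL-60 cells (Homo sapiens) for antiproliferative activity, read by MTT assay, with a stated time of 48 h (a lower number here means a stronger inhibitor, a higher number a weaker inhibitor), compound 2 stands level with compound 1 within the scatter, and these are the only two numbers so far. Compound 3 `CCCCc1ccc2[nH]c(-c3ccc(OC)cc3)c(/C=N/NC(=O)c3cccnc3)c2c1` has pyridin-3-yl in place of 2-methoxyphenyl on a carbonyl carbon. Among the measured compounds shown here, one measured step bears on this (a 1.2-fold lower number from compound 1 to compound 2 (0.09 log units; within the scatter)), a swap on the same carbonyl carbon that brought in no ring with a hetero atom. A small move to a higher number, not beyond the scatter, is therefore expected (a 1.4-fold higher number from compound 2 to compound 3 (0.15 log units; within the scatter)). Compound 3 is estimated at 105 nM (expected range 40 nM to 280 nM).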

Compound 3, half-maximal inhibitory concentration: 50 nM
Beside the measured number, compound 3's estimate is 2.1-fold (0.32 log units) above it, and the stated range covers the measured number.
By their numbers in this assay, from the lowest: compounds 3, 2 and 1 (each within the scatter of the next).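

In this assay, pyridin-3-yl brings the first ring with a hetero atom to this carbonyl carbon, giving a 1.5-fold lower number from compound 2 to compound 3 (0.17 log units; within the scatter) and a 1.8-fold lower number from compound 1 to compound 3 (0.26 log units; within the scatter). Both steps lie within the scatter, so a ring nitrogen here, with a smaller group than 2-methoxyphenyl, leaves the three compounds level. No measurement on hand accounts for this result.

The compounds shown leave open whether pyridin-4-yl would stay level with them. They also do not tell how a non-aromatic group on this carbonyl carbon, such as a piperidine or a short alkyl chain, would read.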